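Swapping Chloro for Methoxy on an Inactive Dithiocarbamate

The compounds below may be only part of what the source reports. "The series", "measured", "known", "first", "only" and "open" are said of these compounds alone.

Of the compounds shown here, two built on a shared core have been tested in a functional assay on PC-3 cells (Homo sapiens) for inhibition, read by MTT assay, with a stated time of 72 h; a higher number here means a weaker inhibitor, a lower number a stronger inhibitor. Compound 1 `Fc1ccc(Cn2cc(CSC(=S)N3CCNCC3)nn2)cc1` carries a fluorine on its benzyl ring. In this assay compound 1 reaches only the limit of > 128000 nM, which is a boundary of the measurement rather than a number. Compound 2 `O=C(OCc1ccccc1)N1CCN(C(=S)SCc2cn(Cc3ccc(Cl)cc3)nn2)CC1` carries a chlorine in the same position and a benzyl carbamate on the piperazine. In this assay compound 2 likewise stops at the limit of > 128000 nM, again a boundary and not a measured value. Both compounds therefore sit at the same ceiling, as the evidence shows: the limit of > 128000 nM in this assay, at which 2 of the 2 values shown sit.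

Compound 3 `COc1ccc(Cn2cc(CSC(=S)N3CCN(C(=O)OCc4ccccc4)CC3)nn2)cc1` is compound 2 with methoxy in place of chloro on an aromatic carbon. Among the measured compounds shown here, no measured pair shows what such a swap does here, so the expected step from compound 2 to compound 3 is none beyond the usual scatter, a step that the limit leaves unreadable from compound 2 to compound 3. Compound 3 is accordingly estimated at 200000 nM in this assay, within a range of 60000 nM to 700000 nM, and most likely reported only as a limit.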

Compound 3, half-maximal inhibitory concentration: > 128000 nM
Compound 3 gave a limit, no number (the forecaster's own chance of this, stated with the estimate: 85%); the middle value does not contradict the limit.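

Compound 2 and compound 3 both stop at the assay's limit, so the swap of chloro for methoxy gives no step that can be read: the limit of > 128000 nM in this assay, at which 3 of the 3 values shown sit.

The compounds shown leave open how strongly any of them inhibits, and whether chloro and methoxy would differ at all once a real number could be read.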